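Changing the Amide Substituent: Expected Solubility of Compound 3

The source may hold more compounds than are shown below. What is called first, only, known or untested is meant among the compounds shown, and "the series" means these compounds.

Compound 1 `COc1ccc(S(=O)(=O)Nc2ccc(CN3CCN(C(=O)C4CC(O)(C(F)(F)F)C4)CC3)cc2)cc1` gives >= 374000 nM in a physicochemical assay for solubility, measured as kinetic solubility; a lower number here means a less soluble compound, a higher number a more soluble compound.
Compound 2 `COc1ccc(S(=O)(=O)Nc2ccc(CN3CC[C@H](NC(=O)c4cccc(Cl)c4)C3)cc2)cc1` gives 51000 nM in this assay.

The value of compound 1 is a limit of the assay, not a number, at the limit of >= 374000 nM in this assay, at which 1 of the 2 values shown sits. Compound 2 gives a real number. Compound 3 `COc1ccc(S(=O)(=O)Nc2ccc(CN3CCN(C(=O)Cn4cccnc4=O)CC3)cc2)cc1` has not been measured; it differs from compound 1 in one place (a group of 8 heavy atoms (5 carbon, 2 nitrogen, 1 oxygen; one six-membered aromatic ring with 2 hetero atoms) in place of a group of 9 heavy atoms (5 carbon, 1 oxygen, 3 fluorine; one four-membered non-aromatic ring of carbon only), on a carbonyl carbon). Within the data shown here, no measured pair differs by a single change, so no step size is known. Starting from compound 1 at the limit of >= 374000 nM in this assay, at which 1 of the 2 values shown sits, the expected step is an at least 1.2-fold lower number from compound 1 to compound 3 (0.09 log units; that floor lies within the scatter), which is not expected to go beyond the usual scatter. Compound 3 is estimated at 300000 nM, between 120000 nM and 400000 nM.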

Compound 3, solubility: >= 336000 nM
Compound 3: only a limit was reported; the forecaster's own chance of this, stated with the estimate: 50%; middle value at least 1.1-fold (0.04 log units) away from the limit.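

Compound 1 and compound 3 each give only a limit of the assay, not a number, so no step can be read between them. As far as these compounds go, how soluble each compound really is, and which is more soluble, stays open.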